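Compound 2 to compound 3: a fluorophenyl swap

The source may report more compounds than this note shows. Statements on the series, on what has been measured and on what is new or still open speak of the compounds shown alone.

Measured in an ADME assay on HepG2 cells (Homo sapiens) for inhibition, read by resazurin assay, with a stated time of 48 h; on this read-out higher numbers stand for an effect only at larger amounts of compound and lower numbers for an effect already at smaller amounts:
compound 1 `O=C(Nc1ccc2sc(-c3ccc(F)cc3)nc2c1)N1CCCCC1`: > 50 uM
compound 2 `O=C(Nc1ccc2sc(-c3cccc(F)c3F)nc2c1)N1CCCC1`: > 50 uM

Compound 2 gives > 50 uM, which is a limit of the assay and not a number. Compound 1 gives > 50 uM, which is likewise a limit. The two measured compounds therefore stand together: the limit of > 50 uM in this assay, at which 2 of the 2 values shown sit. For the measured compounds named here, compound 2 has no number of its own in this assay, and no measured step is available to show how far a structural change can move the read-out.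

Compound 3 `O=C(Nc1ccc2sc(-c3ccc(F)cc3)nc2c1)N1CCCC1` is still to be measured. It carries 4-fluorophenyl in place of 2,3-difluorophenyl on an aromatic carbon, next to the ring nitrogen and next to the ring sulfur: 4-fluorophenyl in place of 2,3-difluorophenyl on an aromatic carbon.

With compound 2 at > 50 uM, the expectation in this assay is no change beyond the scatter and no particular direction. The estimated step is a step that the limit leaves unreadable from compound 2 to compound 3. For compound 3 the expected value is 60 uM, with an estimated range from 30 uM to 100 uM, and a report as a limit is expected to be the likeliest outcome.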

Compound 3, concentration for 90% of the maximal effect: > 50 uM
Compound 3: only a limit was reported (the forecaster's own chance of this, stated with the estimate: 85%); the middle value is on the limit's open side.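

In this assay compound 3 gives > 50 uM, which is a limit of the assay and not a number. No step from compound 1 or compound 2 to compound 3 can be read, as all three compounds stand together: the limit of > 50 uM in this assay, at which 3 of the 3 values shown sit.

The compounds shown leave open whether either swap, 4-fluorophenyl for 2,3-difluorophenyl or pyrrolidin-1-yl for piperidin-1-yl, moves this read-out at all.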